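Fluoro in place of hydrogen on the pendant phenyl

This account rests on a few compounds, and the source may have more. Where it says the series, first, only, none or still open, it means among the compounds named here.

The measured compounds and their values in a functional assay on A549 cells (Homo sapiens) for cytotoxicity, read by MTT assay, with a stated time of 4 days; a higher number here means a weaker inhibitor, a lower number a stronger inhibitor:
compound 1, `Cc1c(O)ccc2c1[C@H](Cn1cc(-c3ccccc3)nn1)[C@@]13CC(=O)[C@@](C)(CC[C@@H]21)C3`, > 20000 nM;
compound 2, `C=C1C(=O)[C@]23C[C@@]1(O)CC[C@H]2c1ccc(OS(=O)(=O)c2ccc(C)cc2)c(C)c1[C@@H]3Cn1cc(-c2ccc(Br)cc2)nn1`, 1630 nM;
compound 3, `C=C1C(=O)[C@]23C[C@@]1(O)CC[C@H]2c1ccc(O)c(C)c1[C@@H]3Cn1cc(-c2ccccc2)nn1`, 1160 nM.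

Compound 1 gives only a limit of the assay, with no number behind it (the limit of > 20000 nM in this assay, at which 1 of the 3 values shown sits). Among the two numbers shown, compound 3 holds the lower one, and its nearest neighbour, compound 2, sits within the scatter of it, so no order between compound 3 and compound 2 can be read from this assay.

Compound 4, `C=C1C(=O)[C@]23C[C@@]1(O)CC[C@H]2c1ccc(O)c(C)c1[C@@H]3Cn1cc(-c2ccc(F)cc2)nn1`, is not yet measured. It differs from compound 3 in one place: fluoro in place of hydrogen on an aromatic carbon. Within the data shown here, no step between measured compounds isolates this change. Compound 2, which carries a bromo group on the same ring together with a second difference, stands within the scatter of compound 3, so a step no larger than the scatter, in either direction, is expected from compound 3 to compound 4 a 1.1-fold lower number from compound 3 to compound 4 (0.02 log units; within the scatter). Compound 4 is therefore estimated at 1100 nM in this assay, within 400 nM to 3500 nM.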

Compound 4, half-maximal inhibitory concentration: 940 nM
The estimate for compound 4 lay 1.2-fold (0.07 log units) above the measured number, and the stated range covers the measured number.
By their numbers in this assay, from the lowest: compounds 4, 3 and 2 (each within the scatter of the next). At a limit, above all of these: compound 1.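

In this assay the change gives a 1.2-fold lower number from compound 3 to compound 4 (0.09 log units; within the scatter) and so provides the first step among these compounds that isolates a single change on the pendant phenyl. On this aromatic carbon, para to a large group, fluoro in place of hydrogen gives no difference that this assay can resolve, and no order can be read between the two compounds. Nothing shown gives a reason for this result.

From the compounds shown here alone, the step to the bromo group of compound 2 cannot be read, as that compound also differs in a second place, so the effect of a bromo group alone remains open. Going by these compounds, whether an amine, a carboxylic acid or a methoxy group on the same carbon would give a number beyond the scatter of compound 3 also remains open.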